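The compounds below may be only part of what the source reports. "The series", "measured", "known", "first", "only" and "open" are said of these compounds alone.

Measured compounds, all in an ADME assay on microsomes from liver (Homo sapiens) for metabolic stability, read by LC-MS, with a stated time of 30 min, tested at 1 uM; a higher number here means that more of the compound is left, a lower number that less of the compound is left:

- Compound 1 `CC(NC(=O)c1cc2cnccc2[nH]1)c1ccc(S(=O)(=O)N2CCCCC2)cc1`: 34%
- Compound 2 `Cn1c(C(=O)NCc2ccc(S(=O)(=O)c3ccccc3)cc2)cc2cnccc21`: 78%
- Compound 3 `O=C(NCc1ccc(S(=O)(=O)c2cc(F)cc(F)c2)cc1)c1cc2cnccc2[nH]1`: 82%

Compound 3, at 82%, cannot be told apart from compound 2, at 78%. The two values lie within the usual scatter of each other. Compound 1, at 34%, stands lower than both, and its gap to compound 3 is beyond the scatter. Compound 3 therefore belongs to the better-preserved pair in this small set.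

Compound 4 `O=C(NCc1ccc(S(=O)(=O)c2cc(F)cc(F)c2)cc1)c1cc2ccncc2o1` is still unmeasured. It keeps the rest of compound 3 and changes only the group on a carbonyl carbon: a group of 9 heavy atoms (7 carbon, 1 nitrogen, 1 oxygen; one five-membered aromatic ring with 1 hetero atom, one six-membered aromatic ring with 1 hetero atom) in place of a group of 9 heavy atoms (7 carbon, 2 nitrogen; one five-membered aromatic ring with 1 hetero atom, one six-membered aromatic ring with 1 hetero atom), on a carbonyl carbon. The two groups match in size and in their ring types, but one nitrogen gives way to one oxygen.

Going by the values given here, no pair of measured compounds shows this kind of swap, so the data offer no direct guide to its effect. The starting point is the value of compound 3, 82%, and a swap this limited suggests a modest move. Expected here is a number 6 percentage points lower from compound 3 to compound 4 (within the scatter), a small downward shift that would probably stay within the scatter. In this assay the estimate for compound 4 is 76%, with an expected range of 55% to 90%.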

Compound 4, percent of the compound remaining: 77%
Compound 4: the middle estimate sits 1 percentage points below what was measured, within the range that was stated.
By their numbers in this assay, from the lowest: compound 1; then compounds 4, 2 and 3 (each within the scatter of the next).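

In this assay, the step at this place reads as a number 5 percentage points lower from compound 3 to compound 4 (within the scatter), and this is the only pair shown that isolates a change on this carbonyl carbon. It shows that, with the rest of compound 3 kept, one nitrogen can give way to one oxygen without a readable difference in this read-out, even though the counts change from 1 hydrogen-bond donor and 1 hydrogen-bond acceptor to 0 hydrogen-bond donors and 2 hydrogen-bond acceptors. Nothing available explains why the two numbers cannot be told apart.

This single pair cannot say whether the same swap would read alike on a compound that differs elsewhere, and compound 1 and compound 2 each differ from compound 3 in more than one place, so neither can test it. On these data alone, it also remains open what the assay would show for a group with a sulfur atom in place of that oxygen, or for a group on the carbonyl carbon that carries an amine or a carboxylic acid.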